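The source may report more compounds than this note shows. Statements on the series, on what has been measured and on what is new or still open speak of the compounds shown alone.

Measured so far in a functional assay on MGC-803 cells (Homo sapiens) for inhibition, read by MTT assay, with a stated time of 72 h; a lower number here means a stronger inhibitor, a higher number a weaker inhibitor:
- compound 1, `Cc1cc(N2CC[C@@H](C)[C@@H](N(C)c3ncnc4[nH]ccc34)C2)n2ncnc2n1`, gives 4350 nM
- compound 2, `Cc1cc(N2CC[C@@H](C)[C@@H](N(C)c3ncnc4[nH]ccc34)C2)n2nc(SCc3cc(Cl)ccc3Cl)nc2n1`, gives 9850 nM
- compound 3, `Cc1cc(N2CC[C@@H](C)[C@@H](N(C)c3ncnc4[nH]ccc34)C2)n2nc(SCc3ccccc3Br)nc2n1`, gives 27000 nM

Compound 3 stands at the highest number of the three, meaning it is the weakest inhibitor of this set: its step from compound 2 is a 2.7-fold higher number from compound 2 to compound 3 (0.44 log units; beyond the scatter), and its step from compound 1 is a 6.2-fold higher number from compound 1 to compound 3 (0.79 log units; beyond the scatter), both beyond the scatter.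

Compound 4, `Cc1cc(N2CC[C@@H](C)[C@@H](N(C)c3ncnc4[nH]ccc34)C2)n2nc(SCc3ccc(F)c(Cl)c3)nc2n1`, is not yet measured. It differs from compound 3 in one place: 3-chloro-4-fluorophenyl in place of 2-bromophenyl on a saturated chain carbon bound to a sulfur.

Going by the values given here, the only measured step that exchanges one halogen-bearing benzyl group for another is a 2.7-fold higher number from compound 2 to compound 3 (0.44 log units; beyond the scatter), a modest shift. The two steps that add a benzylsulfanyl group to the shared core, a 2.3-fold higher number from compound 1 to compound 2 (0.35 log units; beyond the scatter) and a 6.2-fold higher number from compound 1 to compound 3 (0.79 log units; beyond the scatter), show that both substituted benzyl groups tried so far weaken inhibition relative to compound 1. Among the compounds with values here, with only two such groups measured, the pattern of halogens on the ring has moved the number by a modest amount, and a swap of this kind is expected to do no more than that again. The expected step from compound 3 to compound 4 is therefore a 1.8-fold lower number from compound 3 to compound 4 (0.26 log units; within the scatter), in the direction of a lower number, back toward compound 2. Compound 4 is estimated at 15000 nM in this assay, with a range from 6000 nM to 40000 nM.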

Compound 4, half-maximal inhibitory concentration: 52000 nM
For compound 4 the middle estimate is 3.5-fold (0.54 log units) below the measured one; measured number outside the range, above it.
By their numbers in this assay, from the lowest: compound 1; then compound 2; then compounds 3 and 4 (each within the scatter of the next).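

In this assay, a third halogen-bearing benzylsulfanyl group on this aromatic carbon again gives a weaker inhibitor than the hydrogen of compound 1, here with a 12-fold higher number from compound 1 to compound 4 (1.08 log units; beyond the scatter) and the only step of this set marked large, so no compound shown goes against this trend. Changing the halogens does not always register: 2-bromophenyl and 3-chloro-4-fluorophenyl cannot be told apart in this assay, with a 1.9-fold higher number from compound 3 to compound 4 (0.28 log units; within the scatter) as the step between them. Yet the halogen pattern can still matter, since 3-chloro-4-fluorophenyl in place of 2,5-dichlorophenyl gives a 5.3-fold higher number from compound 2 to compound 4 (0.72 log units; beyond the scatter) as a step clearly beyond the scatter, and nothing available explains either result. The compounds shown leave open whether the halogens themselves contribute to the loss, which a plain benzyl group without any halogen would help to separate from the effect of the benzylsulfanyl group as a whole. They also leave open whether anything on this carbon can give a lower number than hydrogen, such as a small amine, a carboxylic acid or a short methyl sulfide.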